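Aryl-Triazole Amide Series: Difluorophenyl Step Expected Small

A few compounds are considered here, and "the series" means these few. Any claim that something is new, unique, unknown or untested is made for them only; others in the source may bear on it.

The measured compounds are: compound 1 `COc1cc2c(Oc3ccc(NC(=O)c4cn(-c5ccc(Br)cc5)nn4)cc3F)ccnc2cc1OCCCN1CCCC1` with 200 nM; compound 2 `COc1cc2c(Oc3ccc(NC(=O)c4cn(-c5c(C)cccc5C)nn4)cc3F)ccnc2cc1OCCCN1CCCC1` with 1560 nM; compound 3 `COc1cc2c(Oc3ccc(NC(=O)c4cn(-c5ccccc5F)nn4)cc3F)ccnc2cc1OCCCN1CCCCC1` with 210 nM.

All three were run in a functional assay on NCI-H460 cells (Homo sapiens) for cytotoxicity, read by MTT assay, with a stated time of 72 h; a higher number here means a weaker inhibitor, a lower number a stronger inhibitor. Compound 3 stands second highest of the three numbers; its nearest neighbour is compound 1, whose number lies within the scatter of that of compound 3, while compound 2 sits well beyond the scatter above both.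

Compound 4 `COc1cc2c(Oc3ccc(NC(=O)c4cn(-c5ccc(F)c(F)c5)nn4)cc3F)ccnc2cc1OCCCN1CCCCC1` has not yet been measured. It differs from compound 3 in one place: 3,4-difluorophenyl in place of 2-fluorophenyl on an aromatic nitrogen.

Among the measured compounds shown here, only one measured step changes the group on that aromatic nitrogen, namely a 7.8-fold higher number from compound 1 to compound 2 (0.89 log units; beyond the scatter), where 2,6-dimethylphenyl replaced 4-bromophenyl. That step involves different groups from the present one, so it bears only loosely on the change from 2-fluorophenyl to 3,4-difluorophenyl. Compound 1 and compound 3, carrying 4-bromophenyl and 2-fluorophenyl, give numbers within the scatter of each other, which suggests that a single fluorophenyl-type group tolerates rearrangement of its fluorine atoms without a large shift.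

Compound 4 is therefore expected to show a step of a 1.2-fold higher number from compound 3 to compound 4 (0.08 log units; within the scatter) in this assay, with no shift beyond the scatter. The number estimated for compound 4 is 250 nM, with a range from 100 nM to 700 nM.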

Compound 4, half-maximal inhibitory concentration: 250 nM
The estimate for compound 4 equals the measured number at the digits printed; the measured number falls inside the stated range.
By their numbers in this assay, from the lowest: compounds 1, 3 and 4 (each within the scatter of the next); then compound 2.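

In this assay, putting 3,4-difluorophenyl in place of 2-fluorophenyl on the aromatic nitrogen gave a 1.2-fold higher number from compound 3 to compound 4 (0.08 log units; within the scatter), so this position accepted a second fluorine and a new fluorine arrangement with no shift beyond the scatter. Among the compounds shown here, the only earlier step at this position, a 7.8-fold higher number from compound 1 to compound 2 (0.89 log units; beyond the scatter), lay beyond the scatter, so the position is now seen to give both outcomes, though with different groups in each step. No measurement at hand accounts for the difference between these two steps.

The compounds shown leave open whether a phenyl ring carrying an amine or a carboxylic acid, or a cyclohexyl group in its place, would keep this level in this assay. From the compounds shown here alone, whether the step seen with 2,6-dimethylphenyl would recur with the side chain of compound 3 also stays open.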